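The source may report more compounds than this note shows. Statements on the series, on what has been measured and on what is new or still open speak of the compounds shown alone.

Measured in a functional assay on UACC-257 cells (Homo sapiens) for cytotoxicity, read by sulforhodamine B assay, with a stated time of 48 h; a higher number here means a weaker inhibitor of growth, a lower number a stronger inhibitor of growth: compound 1 `ClCc1ccc(Cn2cnc3c(Cl)ncnc32)cc1` gives 7410 nM; compound 2 `ClCc1ccccc1Cn1cnc2c(Cl)nc(Cl)nc21` gives 1820 nM; compound 3 `ClCc1ccc(Cn2cnc3nc(Cl)nc(Cl)c32)cc1` gives 2230 nM.

Compound 3 holds the second highest of the three numbers. Its nearest neighbour is compound 2, whose value lies within the scatter of it; compound 1 lies furthest away, with a higher number beyond the scatter.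

Compound 4 `ClCc1ccc(Cn2cnc3ncnc(Cl)c32)cc1` differs from compound 3 in one place: hydrogen in place of chloro on an aromatic carbon, the site being between two ring nitrogen atoms of the six-membered ring of the fused core. Going by the values given here, no pair of measured compounds reports this step, so its size is unknown. Because compound 1 gives 7410 nM and so marks the weak end of the set, compound 4 is expected to move upward, a step of a 2.2-fold higher number from compound 3 to compound 4 (0.35 log units; beyond the scatter) in this assay. Compound 4 is estimated at 5000 nM (range 1800 nM to 14000 nM).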

Compound 4, concentration for 50% growth inhibition: 1580 nM
Compound 4: the middle estimate sits 3.2-fold (0.50 log units) above what was measured, and the stated range ends above it.
By their numbers in this assay, from the lowest: compounds 4, 2 and 3 (each within the scatter of the next); then compound 1.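

In this assay, going by these compounds alone, hydrogen in place of chloro on the aromatic carbon between two ring nitrogen atoms gives the first one-place comparison, and the step, a 1.4-fold lower number from compound 3 to compound 4 (0.15 log units; within the scatter), stays small. At this position in this pair, the chloro group can therefore be lost without a step beyond the scatter. No measurement on hand gives a reason for this result. The compounds shown leave open whether an amine, a methoxy group or a longer chain at this carbon would also stay within the scatter of compound 3. They also leave open whether the same change behaves alike with the benzyl substituent arranged as in compound 2.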